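This account rests on a few compounds, and the source may have more. Where it says the series, first, only, none or still open, it means among the compounds named here.

Compound 1 `C=C(c1ccc(OC)cc1NC(=O)CO)c1ccc(OC)c2c1OC(C)(C)C=C2`: 40 nM
Compound 2 `C=C(c1ccc(OC)cc1NC(=O)CN)c1ccc(OC)c2c1OC(C)(C)C=C2`: 120 nM
Compound 3 `C=C(c1ccc(OC)cc1NC(=O)CNC)c1ccc(OC)c2c1OC(C)(C)C=C2`: 310 nM

In a functional assay on HeLa cells (Homo sapiens) for antiproliferative activity, read by MTT assay, with a stated time of 48 h (a higher number here means a weaker inhibitor, a lower number a stronger inhibitor), compound 3 gives the highest of the three numbers, 310 nM. Compound 4 `C=C(c1ccc(OC)cc1NC(=O)CNCC)c1ccc(OC)c2c1OC(C)(C)C=C2` differs from it by methyl in place of hydrogen on a saturated chain carbon bound to an amine nitrogen, so methylamino becomes ethylamino. The closest measured change is a 2.6-fold higher number from compound 2 to compound 3 (0.41 log units; beyond the scatter), where methyl replaced hydrogen on the amine nitrogen itself. The wider steps a 3.0-fold higher number from compound 1 to compound 2 (0.48 log units; beyond the scatter) and a 7.8-fold higher number from compound 1 to compound 3 (0.89 log units; beyond the scatter) also raised the number. Among the measured compounds shown here, no measured step shows this exact change, so a small further rise is expected, an estimated 1.5-fold higher number from compound 3 to compound 4 (0.16 log units; within the scatter). The estimated value for compound 4 is 450 nM, with an expected range of 200 nM to 1000 nM.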

Compound 4, half-maximal inhibitory concentration: 1090 nM
Estimate against measurement, compound 4: 2.4-fold (0.38 log units) below; the whole stated range lies below it.
By their numbers in this assay, from the lowest: compound 1; then compound 2; then compound 3; then compound 4.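

In this assay, the added methyl on a saturated chain carbon bound to an amine nitrogen gave a 3.5-fold higher number from compound 3 to compound 4 (0.55 log units; beyond the scatter), so the rise does not end with substitution on the nitrogen itself. Ethyl in place of hydrogen on the amine nitrogen gave a 9.1-fold higher number from compound 2 to compound 4 (0.96 log units; beyond the scatter), and ethylamino in place of hydroxy gave a 27-fold higher number from compound 1 to compound 4 (1.44 log units; beyond the scatter), the only step here rated large. No evidence at hand explains this rise. As far as these compounds go, whether a longer chain such as propylamino raises the number further remains open, as does the effect of a branched isopropylamino or a dimethylamino group.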